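Trifluoromethoxy in place of methyl on the ortho substituent

A few compounds are considered here, and "the series" means these few. Any claim that something is new, unique, unknown or untested is made for them only; others in the source may bear on it.

Three measured compounds share one core and differ only in the group that sits on an aromatic carbon of the six-membered ring, ortho to a large group. Compound 3 `Cc1ccccc1-c1cc2cc(CCC(=O)O)ccc2[nH]1` carries a methyl there, and in a functional assay on CHO cells for agonist activity at Free fatty acid receptor 1 (Homo sapiens), read by a luciferase reporter, with a stated time of 24 h (on this read-out higher numbers stand for an effect only at larger amounts of compound and lower numbers for an effect already at smaller amounts), compound 3 gives 447 nM. Compound 2 `CCc1ccccc1-c1cc2cc(CCC(=O)O)ccc2[nH]1` carries an ethyl and gives 1800 nM in this assay. Compound 1 `CC(C)c1ccccc1-c1cc2cc(CCC(=O)O)ccc2[nH]1` carries an isopropyl, and in this assay compound 1 gives a value that is a limit, > 25 nM. Compound 3 thus holds the lowest of the two readable numbers, set apart from compound 2 by a 4.0-fold lower number from compound 2 to compound 3 (0.60 log units; beyond the scatter), while a step that the limit leaves unreadable from compound 1 to compound 3 cannot be sized. Compound 4 `O=C(O)CCc1ccc2[nH]c(-c3ccccc3OC(F)(F)F)cc2c1` differs from compound 3 in one place: trifluoromethoxy in place of methyl on an aromatic carbon. Within the data shown here, the only step that can be read, a 4.0-fold lower number from compound 2 to compound 3 (0.60 log units; beyond the scatter), went downward when a methyl left the chain on that carbon, and trifluoromethoxy brings more heavy atoms than the methyl it replaces, so a step upward is expected for compound 4, of about a 3.4-fold higher number from compound 3 to compound 4 (0.53 log units; beyond the scatter). Compound 4 is therefore estimated to give 1500 nM, with a likely range from 300 nM to 8000 nM.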

Compound 4, half-maximal effective concentration: 1020 nM
The estimate for compound 4 lay 1.5-fold (0.17 log units) above the measured number; the range from low to high includes it.
By their numbers in this assay, from the lowest: compound 3; then compounds 4 and 2 (each within the scatter of the next).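

Replacing methyl with trifluoromethoxy, which brings five heavy atoms in place of one, gives a 2.3-fold higher number from compound 3 to compound 4 (0.36 log units; beyond the scatter), so the low number of compound 3 is not kept when this larger group enters at this place. Set against the ethyl group, the same group gives a 1.8-fold lower number from compound 2 to compound 4 (0.25 log units; within the scatter), so compound 2 and compound 4 cannot be told apart in this assay, and the methyl of compound 3 stands apart from both. The steps from compound 1 cannot be read, because its value is a limit and not a number: the limit of > 25 nM in this assay, at which 1 of the 4 values shown sits.

The compounds shown leave open how a methoxy group, which has the oxygen but no fluorine, would read at this place. They also leave open what a single fluorine or a nitrile would give there.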